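Triazole series: aryl swap at the triazole carbon

The source may report more compounds than this note shows. Statements on the series, on what has been measured and on what is new or still open speak of the compounds shown alone.

Measured so far:
- Compound 1 `COc1ccccc1-c1ncnn1-c1cc(OC)c(OC)c(OC)c1`, in a functional assay on A549 cells (Homo sapiens) for antiproliferative activity, read by MTT assay, with a stated time of 72 h (on this read-out higher numbers stand for weaker inhibition and lower numbers for stronger inhibition), compound 1 gives > 10000 nM, which is a limit of the assay.
- Compound 2 `COc1cc(-n2ncnc2-c2ccc(Cl)c(Cl)c2)cc(OC)c1OC`, in this assay compound 2 gives > 10000 nM, which is a limit of the assay.

Among the measured compounds shown here, compound 2 stands at the limit of the assay, and so does the only other value shown, as the limit of > 10000 nM in this assay, at which 2 of the 2 values shown sit, records. For the measured compounds named here, the one measured step, a step that the two limits leave unreadable from compound 1 to compound 2, is therefore unreadable in size and direction.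

Compound 3 `COc1cccc(-c2ncnn2-c2cc(OC)c(OC)c(OC)c2)c1` is not yet measured. It differs from compound 2 by 3-methoxyphenyl in place of 3,4-dichlorophenyl on an aromatic carbon. Going by the values given here, the only step that bears on this change is a step that the two limits leave unreadable from compound 1 to compound 2, and it is unreadable; compound 1, which carries a 2-methoxyphenyl at the same place, also sits at the limit. Nothing shown separates one aryl group from another at this position.

Compound 3 is therefore expected to remain near the limit, with the step that the limit leaves unreadable from compound 2 to compound 3 expected to be nothing beyond the scatter. The estimate for compound 3 in this assay is 15000 nM, in the range 4000 nM to 60000 nM, with a high chance that only a limit is reported.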

Compound 3, half-maximal inhibitory concentration: > 10000 nM
Compound 3: only a limit was reported (the forecaster's own chance of this, stated with the estimate: 70%); the middle value lies beyond the limit too.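

In this assay compound 3 gives > 10000 nM, which is a limit of the assay. No step among compound 1, compound 2 and compound 3 can be read, in size or in direction: the limit of > 10000 nM in this assay, at which 3 of the 3 values shown sit.

The compounds shown leave open whether any aryl group at this place on the shared core gives a measurable value in this assay.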